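Pyrrolidinyl for morpholinylcarbonylmethyl on the ring nitrogen

The source may report more compounds than this note shows. Statements on the series, on what has been measured and on what is new or still open speak of the compounds shown alone.

Measured compounds:
compound 1 `O=C(Cc1nn(CC(=O)N2CCOCC2)c(=O)c2ccccc12)Nc1ccc(OC(F)(F)F)c(Cl)c1` — 30 nM
compound 2 `O=C(O)Cn1nc(Cc2nc3cc(F)c(OCC4CC4)cc3[nH]2)c2ccccc2c1=O` — 18 nM

In a functional assay on CHO cells for antagonist activity at sphingosine 1-phosphate receptor 2 (Homo sapiens), read by calcium flux (on this read-out lower numbers stand for stronger inhibition and higher numbers for weaker inhibition), compound 1 gives 30 nM, the higher of the two numbers; compound 2 gives 18 nM, and the two values lie within the scatter of each other. Compound 3 `O=C(Cc1nn(C2CCNC2)c(=O)c2ccccc12)Nc1ccc(OC(F)(F)F)c(Cl)c1` differs from compound 1 by pyrrolidin-3-yl in place of ((morpholin-4-yl)carbonyl)methyl on an aromatic nitrogen. For the measured compounds named here, no measured pair shows this change, so its effect is unknown. The step from compound 1 to compound 3 in this assay is expected to be small, a 1.3-fold higher number from compound 1 to compound 3 (0.12 log units; within the scatter), and not clearly beyond the scatter in either direction. Compound 3 is therefore estimated at 40 nM, with a range from 10 nM to 160 nM.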

Compound 3, half-maximal inhibitory concentration: 94 nM
Beside the measured number, compound 3's estimate is 2.4-fold (0.37 log units) below it; low and high end bracket the measured number.
By their numbers in this assay, from the lowest: compounds 2 and 1 (each within the scatter of the next); then compound 3.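

In this assay, the group on the aromatic nitrogen proves able to shift the number: pyrrolidin-3-yl in place of ((morpholin-4-yl)carbonyl)methyl gives a 3.1-fold higher number from compound 1 to compound 3 (0.50 log units; beyond the scatter) as a modest step beyond the scatter. This position therefore does not take this change without some loss of inhibition. Nothing at hand bears on why the number rises. The compounds shown leave open whether a piperidin-4-yl ring, a dimethylamino-bearing chain or a simple methyl on this nitrogen would give a lower or higher number than either group.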